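Changing the Sulfonyl Ring on a Shared Core

The source may report more compounds than this note shows. Statements on the series, on what has been measured and on what is new or still open speak of the compounds shown alone.

Of the compounds shown here, three sharing one core have been measured in an ADME assay on microsomes from liver (Homo sapiens) for pharmacokinetics, read by LC-MS, with a stated time of 60 min, tested at 1 uM; on this read-out lower numbers stand for slow clearance and higher numbers for fast clearance. Compound 1 `CCCn1cc(S(=O)(=O)c2ccc(CNC(=O)N3Cc4ccncc4C3)cc2)cn1` gives 11 mL/min/kg, compound 2 `CC(C)n1cc(S(=O)(=O)c2ccc(CNC(=O)N3Cc4ccncc4C3)cc2)cn1` gives 4 mL/min/kg, and compound 3 `O=C(NCc1ccc(S(=O)(=O)C2CCC(F)(F)CC2)cc1)N1Cc2ccncc2C1` gives 6 mL/min/kg. Compound 3 therefore lies within the scatter of both other compounds. Compound 4 `O=C(NCc1ccc(S(=O)(=O)C2CCOCC2)cc1)N1Cc2ccncc2C1` differs from compound 3 by oxan-4-yl in place of 4,4-difluorocyclohexyl on a sulfonyl sulfur, with oxan-4-yl in place of 4,4-difluorocyclohexyl on a sulfonyl sulfur.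

Two measured steps changed the group at this place: a 1.8-fold lower number from compound 1 to compound 3 (0.26 log units; within the scatter) and a 1.5-fold higher number from compound 2 to compound 3 (0.18 log units; within the scatter). Neither went beyond the scatter, although both replaced a substituted pyrazolyl group with 4,4-difluorocyclohexyl. For the measured compounds named here, the only larger step, a 2.8-fold lower number from compound 1 to compound 2 (0.44 log units; beyond the scatter), is modest and involves isopropyl in place of propyl on an aromatic nitrogen, a change elsewhere in the structure. Going by the values given here, no measured step tests oxan-4-yl itself, so the expectation remains tentative. The expected step is a 1.2-fold lower number from compound 3 to compound 4 (0.08 log units; within the scatter), which would not exceed the scatter. For compound 4 the estimated clearance is 5 mL/min/kg, with an expected range from 2.5 mL/min/kg to 10 mL/min/kg.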

Compound 4, clearance: 6 mL/min/kg
Compound 4: the middle estimate sits 1.2-fold (0.08 log units) below what was measured; low and high end bracket the measured number.
By their numbers in this assay, from the lowest: compounds 2, 3, 4 and 1 (each within the scatter of the next, the first and the last beyond it).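

Oxan-4-yl on the sulfonyl sulfur adds a second non-aromatic ring to the comparison in this assay: in place of 4,4-difluorocyclohexyl, a ring of carbon only, this ring with its hetero atom and hydrogen-bond acceptor gives no change at the digits printed from compound 3 to compound 4 (within the scatter). Against the two pyrazolyl groups, oxan-4-yl gives a 1.5-fold higher number from compound 2 to compound 4 (0.18 log units; within the scatter) and a 1.8-fold lower number from compound 1 to compound 4 (0.26 log units; within the scatter), so every step shown between a pyrazolyl group and a non-aromatic ring stays within the scatter, while only the step between the propyl and isopropyl pyrazolyl compounds goes beyond it. The information available gives no reason for this result.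

Going by these compounds, it remains open whether a ring bearing an amine or a carboxylic acid would keep clearance within this range. The same question stands for an open longer chain on the sulfonyl sulfur.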